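This account rests on a few compounds, and the source may have more. Where it says the series, first, only, none or still open, it means among the compounds named here.

Working notes on the series. Compound 1, `COc1ccc(C2N=C(SCc3ccccc3)NC(C)=C2C(=O)Nc2ccc(F)cc2)cc1OC`, is the reference point: in a functional assay on the whole organism (artery, strain albino) with Rattus norvegicus as the target, with a stated time of 900 min, at a dose of 10 mg/kg by the oral route (a lower number here means less inhibition, a higher number more inhibition at the dose given (going by the name of the read-out)), compound 1 gives 1%. Within the data shown here, compound 2, `COc1ccc(C2N=C(SCc3cccc(Cl)c3)NC(C)=C2C(=O)Nc2ccc(F)cc2)cc1OC`, carries the change (chloro in place of hydrogen on an aromatic carbon), and in this assay compound 2 gives 13.3%; the step of a number 12.3 percentage points higher from compound 1 to compound 2 (beyond the scatter) is the only measured instance of this change so far.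

Compound 3, `CC1=C(C(=O)Nc2ccc([N+](=O)[O-])cc2)C(c2cccc([N+](=O)[O-])c2)N=C(SCc2ccccc2)N1`, has a different core; how the core of compound 3 differs from that of compound 1 is not broken down here. In this assay compound 3 gives 14.9%, which sits within the scatter of compound 2 and beyond the scatter above compound 1.

Compound 4, `CC1=C(C(=O)Nc2ccc([N+](=O)[O-])cc2)C(c2cccc([N+](=O)[O-])c2)N=C(SCc2ccccc2Cl)N1`, is not yet measured and is made from compound 3 by chloro in place of hydrogen on an aromatic carbon. Against the change from compound 1 to compound 2 this is the same kind of change, not the same: there the chloro enters meta to a large group, here ortho to a large group.

The step from compound 3 to compound 4 is expected to be a number 7.1 percentage points higher from compound 3 to compound 4 (within the scatter), a somewhat smaller move than the earlier one, resting on the step of a number 12.3 percentage points higher from compound 1 to compound 2 (beyond the scatter) and on the changed place of the chloro. Compound 4 is therefore estimated at 22%, expected between 5% and 40%.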

Compound 4, a percentage reported as inhibition, in the whole organism at one dose (the size of the read-out at that dose, not a potency): 7.2%
Beside the measured number, compound 4's estimate is 14.8 percentage points above it, within the range that was stated.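

Among these compounds, on the core of compound 3, chloro in place of hydrogen on an aromatic carbon gives a number 7.7 percentage points lower from compound 3 to compound 4 (within the scatter) and so no step that can be told from the scatter. The two steps also differ in the place of the chloro, which in compound 4 is ortho to a large group, so the data do not separate the part played by the core from the part played by that place, and one step per core sets no rule for either. What can be said is that the change does not carry over as a fixed increment between these two cores:  the same change on two cores in this assay, a number 12.3 percentage points higher (beyond the scatter) from compound 1 to compound 2 and a number 7.7 percentage points lower (within the scatter) from compound 3 to compound 4, 20 percentage points apart, beyond the scatter of two such steps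

The compounds shown leave open whether a chloro at one and the same place would give matching steps on both cores. They also leave open how the number in this assay responds when the benzyl part of the benzylsulfanyl group carries something other than chloro, such as an amine or a carboxylic acid, or gives way to a longer chain.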